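This account rests on a few compounds, and the source may have more. Where it says the series, first, only, none or still open, it means among the compounds named here.

In a functional assay on the whole organism for positive allosteric modulation, with Mus musculus as the target (on this read-out higher numbers stand for an effect only at larger amounts of compound and lower numbers for an effect already at smaller amounts), compound 3 (`CCC(=O)N(c1ccc(Cl)c(Cl)c1)C1CCCC1N(C)CCN(C)C`) gives 20 mg/kg as the higher of the two actual numbers in this small set. Compound 2 (`C=CCN(C)C1CCCC1N(C(=O)CC)c1ccc(Cl)c(Cl)c1`) gives 6 mg/kg on the same read-out. For compound 1 (`CCCN(CCC)C1CCCC1N(C(=O)CC)c1ccc(Cl)c(Cl)c1`) the assay reports > 50 mg/kg as a limit and not a number. Both steps that start from this limit are therefore bounds rather than exact sizes: an at least 8.3-fold lower number from compound 1 to compound 2 (0.92 log units; beyond the scatter) and an at least 2.5-fold lower number from compound 1 to compound 3 (0.39 log units; beyond the scatter) show that replacing dipropylamino helped in each case.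

Compound 4 (`CCC(=O)N(c1ccc(Cl)c(Cl)c1)C1CCCC1N(C)CCCN(C)C`) differs from compound 3 in one place: (dimethylamino)methyl in place of dimethylamino on a saturated chain carbon, two bonds along the chain from an amine nitrogen and thus (2-(dimethylamino)ethyl)(methyl)amino becomes (3-(dimethylamino)propyl)(methyl)amino. Within the data shown here, no measured step covers this change directly. The nearest is the modest 3.3-fold higher number from compound 2 to compound 3 (0.52 log units; beyond the scatter) and it alters the same amine substituent, though it exchanges vinyl rather than extending a chain. Since that step is modest and the new change is small, the expected step in this assay is a 1.3-fold higher number from compound 3 to compound 4 (0.10 log units; within the scatter) and no shift beyond the scatter is expected, with a slight lean toward a higher number. For compound 4 the estimate is 25 mg/kg with an expected range from 8 mg/kg to 60 mg/kg in this read-out.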

Compound 4, dose for half-maximal effect: 30 mg/kg
For compound 4 the middle estimate is 1.2-fold (0.08 log units) below the measured one; the measured number falls inside the stated range.
By their numbers in this assay, from the lowest: compound 2; then compounds 3 and 4 (each within the scatter of the next). At a limit, above all of these: compound 1.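

In this assay, (dimethylamino)methyl in place of dimethylamino on a saturated chain carbon, two bonds along the chain from an amine nitrogen, does not move the read-out beyond the scatter: a 1.5-fold higher number from compound 3 to compound 4 (0.18 log units; within the scatter). The gap to the allyl(methyl)amino of compound 2 also holds for this second chain ending in dimethylamino, and it is beyond the scatter: a 5.0-fold higher number from compound 2 to compound 4 (0.70 log units; beyond the scatter). Compound 1 stands at a limit and not a number: the limit of > 50 mg/kg in this assay, at which 1 of the 4 values shown sits. The step from that limit is only a bound, its floor lies within the scatter, and it cannot be read as a size: an at least 1.6-fold lower number from compound 1 to compound 4 (0.22 log units; that floor lies within the scatter).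

The compounds shown leave open whether a 4-(dimethylamino)butyl chain would stay level with compounds 3 and 4, and whether a pyrrolidine or morpholine at the chain end in place of dimethylamino would change the number. They also leave open whether the allyl group of compound 2 matters as such, since a saturated propyl(methyl)amino group in its place would be needed to separate the double bond from the length of the chain.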